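The source may hold more compounds than are shown below. What is called first, only, known or untested is meant among the compounds shown, and "the series" means these compounds.

Working notes on the series. Among the measured compounds shown here, compound 1 `O=C(NCc1ccncc1)Nc1ccc(S(=O)(=O)Nc2ccccc2)cc1` gives 410 nM in an assay on isolated protein for activation of Nicotinamide phosphoribosyltransferase (Homo sapiens) (a higher number here means that more compound is needed for the effect, a lower number that less compound is needed), the higher of the two numbers measured so far. For the measured compounds named here, compound 2 `O=C(NCc1cnco1)Nc1ccc(S(=O)(=O)c2ccccc2)cc1` gives 77 nM in this assay, a lower number by a margin beyond the scatter, but compound 2 differs from compound 1 in more than one place, so no single step between measured compounds can be read from the pair.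

Compound 3 `O=C(NCc1ccncc1)Nc1ccc(S(=O)(=O)N2CCc3ccccc3C2)cc1` is not yet measured. It carries 1,2,3,4-tetrahydroisoquinolin-2-yl in place of anilino on a sulfonyl sulfur. Going by the values given here, no measured pair isolates this change, so its effect has to be guessed. The expectation for compound 3 is a step from compound 1 of a 1.4-fold lower number from compound 1 to compound 3 (0.14 log units; within the scatter), leaning slightly toward a lower number but not with confidence beyond the scatter. Compound 3 is therefore expected at about 300 nM in this assay, with a range from 100 nM to 1000 nM.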

Compound 3, half-maximal effective concentration: 142 nM
For compound 3 the middle estimate is 2.1-fold (0.32 log units) above the measured one; the range from low to high includes it.
By their numbers in this assay, from the lowest: compounds 2 and 3 (each within the scatter of the next); then compound 1.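

Among the compounds shown here, on a sulfonyl sulfur, 1,2,3,4-tetrahydroisoquinolin-2-yl in place of anilino gives a 2.9-fold lower number from compound 1 to compound 3 (0.46 log units; beyond the scatter) in this assay, the first step that isolates a change at a single place. This place therefore accepts a group of 10 heavy atoms with 0 hydrogen-bond donors, and the number does not rise when anilino, with its 1 hydrogen-bond donor, leaves. No measurement here bears on why the number falls, and the loss of the donor, the larger group and the added non-aromatic ring all arrive in the same step.

Which of these differences carries the step remains open: N-methylanilino would remove the donor while keeping the aromatic ring on the nitrogen, and piperidin-1-yl would keep the non-aromatic ring without the fused aromatic one. Going by these compounds, whether the step holds with groups other than the pyridinylmethyl urea of compound 1 is also open.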